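Bromo added to an inactive compound

The compounds below may be only part of what the source reports. "The series", "measured", "known", "first", "only" and "open" are said of these compounds alone.

Compound 1 `COc1cc(-c2ocnc2-c2cc(Br)c(OC)c(OC)c2)ccc1SC`: > 20000 nM
Compound 2 `COc1cc(-c2ocnc2-c2cc(OC)c(OC)c(OC)c2)ccc1SC`: > 20000 nM

In a functional assay on A549 cells (Homo sapiens) for cytotoxicity, read by MTT assay, with a stated time of 48 h (a lower number here means a stronger inhibitor, a higher number a weaker inhibitor), neither result is a number: the limit of > 20000 nM in this assay, at which 2 of the 2 values shown sit. Compound 2 therefore stands only at the limit of > 20000 nM. Compound 3 `COc1cc(-c2ncoc2-c2cc(Br)c(SC)c(OC)c2)cc(OC)c1OC` differs from compound 2 by one change: bromo in place of hydrogen on an aromatic carbon, with the bromo ortho to a methylsulfanyl group. Among the compounds with values here, the only measured step, a step that the two limits leave unreadable from compound 1 to compound 2, has no readable size, so it offers no size or direction to carry over. Compound 3 is therefore expected to remain weak, probably at the same limit. The expected step is a number no higher from compound 2 to compound 3 (the limit leaves the size open), a rough estimate. For compound 3, the estimate is 20000 nM, with an expected range of 3000 nM to 50000 nM.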

Compound 3, half-maximal inhibitory concentration: > 20000 nM
Compound 3: no number, only a limit; the forecaster's own chance of this, stated with the estimate: 70%; the middle value sits exactly at the limit.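

Compound 2 and compound 3 both give only a limit in this assay, so no step between them can be read: the limit of > 20000 nM in this assay, at which 3 of the 3 values shown sit.

The compounds shown leave open whether adding bromo changes activity at all, since any real effect would lie beyond that limit.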